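The compounds below may be only part of what the source reports. "The series", "measured", "known", "first", "only" and "open" are said of these compounds alone.

Working notes on a series built on one shared core. Compound 1 is `Cc1cc(NNC(=O)Nc2cc(Cl)nc(Cl)c2)ncc1N(C)C`, compound 2 is `Cc1cc(NNC(=O)Nc2cc(Cl)nc(Cl)c2)ncc1C#N` and compound 3 is `Cc1cc(NNC(=O)Nc2cc(Cl)nc(Cl)c2)ncc1-c1ccn(C)n1`. All three have been run in a functional assay on CHO cells for agonist activity at sphingosine 1-phosphate receptor 2 (Homo sapiens), read by fluorescence and calcium flux, with a stated time of 3 min; a higher number here means a weaker inhibitor, a lower number a stronger inhibitor. In this assay compound 1 returns only a limit of the assay, > 23000 nM. Compound 2 in this assay likewise returns a limit, > 23000 nM. Compound 3 in this assay also returns a limit, > 23000 nM. So compound 3 stands at the limit of > 23000 nM in this assay, at which 3 of the 3 values shown sit, with no number of its own to place it against the other two. The steps between the measured compounds, a step that the two limits leave unreadable from compound 1 to compound 2, a step that the two limits leave unreadable from compound 1 to compound 3 and a step that the two limits leave unreadable from compound 2 to compound 3, are all of unreadable size for the same reason: every value is a limit. Compound 4 is `Cc1cc(NNC(=O)Nc2cc(Cl)nc(Cl)c2)ncc1-c1cn(C)nc1C`; it differs from compound 3 by 1,3-dimethyl-1H-pyrazol-4-yl in place of 1-methyl-1H-pyrazol-3-yl on an aromatic carbon. No measured step reads on this change, and nothing shown speaks for a gain in potency. Compound 4 is therefore expected to sit near the limit as well, with a step that the limit leaves unreadable from compound 3 to compound 4 expected to be no more than scatter. The estimate for compound 4 in this assay is 30000 nM, within a range from 8000 nM to 120000 nM.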

Compound 4, half-maximal inhibitory concentration: > 23000 nM
Compound 4 gave a limit, no number; the forecaster's own chance of this, stated with the estimate: 85%; the middle value does not contradict the limit.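

No new step can be read for compound 4 against compound 1, compound 2 or compound 3 in this assay, because all four values are limits of the assay: the limit of > 23000 nM in this assay, at which 4 of the 4 values shown sit.

The compounds shown leave open whether any group at this place on the shared core gives a measurable value.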